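This account rests on a few compounds, and the source may have more. Where it says the series, first, only, none or still open, it means among the compounds named here.

Compounds measured in a physicochemical assay for acid dissociation:
Compound 1 `COc1cccc(Oc2ccc3c(NCCCNCc4cccc(OC)c4O)ccnc3c2)c1`: 9.28
Compound 2 `COc1cccc(CNCCCNc2ccnc3cc(Oc4ccc(C(C)(C)C)cc4)ccc23)c1O`: 9.28
Compound 3 `c1coc(CNCCCNc2ccnc3cc(C4CCCCC4)ccc23)c1`: 9.47

Compound 3 holds the highest of the three readings in this assay, but its gaps to compound 1 and to compound 2 both fall within the usual scatter, so the three stand together. For the measured compounds named here, the one single-point step measured so far, no change at the digits printed from compound 1 to compound 2 (within the scatter), concerns the group on the aromatic oxygen and not the chain end, so it bears on the present step only in showing that the series tolerates a change elsewhere without moving.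

Compound 4 `COc1cccc(CNCCCNc2ccnc3cc(C4CCCCC4)ccc23)c1O` differs from compound 3 at the chain end: 2-hydroxy-3-methoxyphenyl in place of furan-2-yl on a saturated chain carbon bound to an amine nitrogen. Compound 1 and compound 2 already carry the 2-hydroxy-3-methoxyphenyl group on the saturated chain carbon bound to the amine nitrogen, and their readings sit within the scatter of compound 3, which carries furan-2-yl there. Nothing measured separates the two chain-end groups beyond the scatter, so no step beyond the scatter is expected in this assay in either direction. Compound 4 is therefore expected to give 9.3, within 8.9 to 9.7. The expected step is a number 0.17 log units lower from compound 3 to compound 4 (within the scatter).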

Compound 4, acid dissociation constant: 9.47
Estimate against measurement, compound 4: 0.17 log units below, within the range that was stated.
By their numbers in this assay, from the lowest: compounds 1, 2, 3 and 4 (each within the scatter of the next).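

In this assay, the chain-end change is now read directly on one shared core, and 2-hydroxy-3-methoxyphenyl in place of furan-2-yl gives no change at the digits printed from compound 3 to compound 4 (within the scatter) so the two groups are not told apart at this position. With 2-hydroxy-3-methoxyphenyl held fixed, cyclohexyl on an aromatic carbon gives a number 0.19 log units higher from compound 2 to compound 4 (within the scatter) in place of 4-(tert-butyl)phenoxy and a number 0.19 log units higher from compound 1 to compound 4 (within the scatter) in place of 3-methoxyphenoxy so neither the chain-end change nor these aromatic-carbon changes step beyond the scatter. No measurement offered here accounts for this insensitivity.

The compounds shown leave open whether a carboxylic acid or a second amine on the saturated chain carbon, or a longer chain on the amine nitrogen, would give a step beyond the scatter. They also do not show which proton the reading belongs to.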